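Ester in place of amine on the long chain

The source may report more compounds than this note shows. Statements on the series, on what has been measured and on what is new or still open speak of the compounds shown alone.

Compound 2 `CCCCCCCCCCCC[C@@H](O)[C@H]1CC[C@H]([C@H](O)CCCCCCCCCCNCc2ccnn2C)O1` holds the lowest of the two numbers in a functional assay on KM12 cells (Homo sapiens) for inhibition, read by sulforhodamine B assay, with a stated time of 48 h (on this read-out lower numbers stand for stronger inhibition of growth and higher numbers for weaker inhibition of growth), giving 1410 nM, while compound 1 `CCCCCCCCCCCC[C@@H](O)[C@H]1CC[C@H]([C@H](O)CCCCCCCCCCNC(=O)c2ccnn2C)O1` gives 100000 nM. Compound 3 `CCCCCCCCCCCC[C@@H](O)[C@H]1CC[C@H]([C@H](O)CCCCCCCCCCOC(=O)c2ccnn2C)O1` differs from compound 2 by ((1-methyl-1H-pyrazol-5-yl)carbonyl)oxy in place of ((1-methyl-1H-pyrazol-5-yl)methyl)amino on a saturated chain carbon, ten or more bonds along the chain from an oxygen on a saturated carbon and a saturated ring carbon. Going by the values given here, only one measured step bears on this change, and it was large: a 71-fold lower number from compound 1 to compound 2 (1.85 log units; beyond the scatter). Because a 71-fold lower number from compound 1 to compound 2 (1.85 log units; beyond the scatter) accompanied the loss of a carbonyl at that nitrogen, compound 3, which again carries a carbonyl on the chain end, is expected to show weaker inhibition, a step of an 18-fold higher number from compound 2 to compound 3 (1.25 log units; beyond the scatter). Compound 3 is thus estimated at 25000 nM, within 4000 nM to 100000 nM.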

Compound 3, concentration for 50% growth inhibition: 20000 nM
The estimate for compound 3 lay 1.3-fold (0.10 log units) above the measured number, and the stated range covers the measured number.
By their numbers in this assay, from the lowest: compound 2; then compound 3; then compound 1.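

In this assay, replacing the amine link with the ester gave a 14-fold higher number from compound 2 to compound 3 (1.15 log units; beyond the scatter), so inhibition fell with a carbonyl on the chain end whether oxygen or nitrogen joined it to the chain. The two carbonyl compounds still differ, with a 5.0-fold lower number from compound 1 to compound 3 (0.70 log units; beyond the scatter), so the atom joining the carbonyl to the chain also counts here. No evidence on hand accounts for these differences. Going by these compounds, it remains open whether a plain ether, without the carbonyl, or a tertiary amine at this place would match compound 2, and whether a longer chain would alter the order.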